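Moving a Methoxy Group on the Outer Phenyl Ring

This account rests on a few compounds, and the source may have more. Where it says the series, first, only, none or still open, it means among the compounds named here.

Of the compounds shown here, three sharing one core have been measured in a functional assay on HL-60 cells (Homo sapiens) for antiproliferative activity, with a stated time of 24 h; on this read-out higher numbers stand for weaker inhibition and lower numbers for stronger inhibition. Compound 1 `NC(=O)c1c(NC(=O)c2ccccc2Cl)sc2c1CCN(Cc1ccc([N+](=O)[O-])cc1)C2` gives 11400 nM, compound 2 `NC(=O)c1c(NC(=O)c2ccccc2Cl)sc2c1CCN(C(=O)Nc1ccccc1Cl)C2` gives 12500 nM, and compound 3 `COc1ccccc1NC(=S)N1CCc2c(sc(NC(=O)c3ccccc3Cl)c2C(N)=O)C1` gives 40900 nM. Compound 3 thus stands highest of the three: the step of a 3.6-fold higher number from compound 1 to compound 3 (0.55 log units; beyond the scatter) and the step of a 3.3-fold higher number from compound 2 to compound 3 (0.51 log units; beyond the scatter) are both modest but beyond the scatter, whereas the step of a 1.1-fold higher number from compound 1 to compound 2 (0.04 log units; within the scatter) stays within it. Compound 4 `COc1ccc(NC(=S)N2CCc3c(sc(NC(=O)c4ccccc4Cl)c3C(N)=O)C2)cc1` differs from compound 3 in one place only: 4-methoxyphenyl in place of 2-methoxyphenyl on an amide-type nitrogen. Among the compounds with values here, none of the measured steps bears directly on this change; each of them swaps the whole group on the ring amine nitrogen rather than shifting a methoxy group around a phenyl ring, so there is no measured guide to its size. Within the data shown here, the two steps into compound 3 show only that the member carrying the thiocarbonyl sits at the high end of the numbers. For compound 4 the expected step is a 1.0-fold lower number from compound 3 to compound 4 (0.01 log units; within the scatter), which is estimated to stay within the scatter. The estimated value for compound 4 in this assay is 40000 nM, within a range from 15000 nM to 110000 nM.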

Compound 4, half-maximal inhibitory concentration: 15700 nM
Beside the measured number, compound 4's estimate is 2.5-fold (0.41 log units) above it; measured number inside the range.
By their numbers in this assay, from the lowest: compounds 1, 2 and 4 (each within the scatter of the next); then compound 3.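

In this assay, moving the methoxy group around the outer phenyl ring proves to be a real change in its own right (a 2.6-fold lower number from compound 3 to compound 4 (0.42 log units; beyond the scatter)), even though compound 3 and compound 4 hold the same atoms. The earlier steps shown here each swapped the whole group on the ring amine nitrogen, whereas this one shows that the choice between 2-methoxyphenyl and 4-methoxyphenyl on the amide-type nitrogen can alone shift the number. It also shows that the thiocarbonyl link does not by itself put a compound at the high end (a 1.3-fold higher number from compound 2 to compound 4 (0.10 log units; within the scatter); a 1.4-fold higher number from compound 1 to compound 4 (0.14 log units; within the scatter)), and no measurement at hand explains the difference between the two methoxy placements.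

The compounds shown leave open how an ethoxy, a hydroxyl or an amine would behave in place of the methoxy group. They also leave open whether the same shift would matter with a chlorine on the outer phenyl ring.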